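Chloro for Ethyl on the Sulfonamide Ring

The source may hold more compounds than are shown below. What is called first, only, known or untested is meant among the compounds shown, and "the series" means these compounds.

Going by the values given here, compound 2 `CCc1ccc(S(=O)(=O)N[C@H]2C3CC[C@H](C3)[C@@H]2C/C=C\CCCC(=O)O)cc1` is the only compound here with a number in a functional assay (plasma) for inhibition, with Oryctolagus cuniculus as the target; on this read-out lower numbers stand for stronger inhibition and higher numbers for weaker inhibition: compound 2 gives 4600 nM. Compound 1 `CC1(C)[C@H]2C[C@H](NC(=O)[C@H](O)C3CCCC3)[C@@H](C/C=C\CCCC(=O)O)[C@@H]1C2` gives > 800000 nM, a limit of the assay and not a number. Compound 3 `O=C(O)CCC/C=C\C[C@H]1[C@@H]2CCC(C2)[C@@H]1NS(=O)(=O)c1ccc(Cl)cc1` differs from compound 2 by chloro in place of ethyl on an aromatic carbon. Among the compounds with values here, no measured pair shows this change, so the expectation rests on compound 2 alone. The expected step of a 1.5-fold lower number from compound 2 to compound 3 (0.19 log units; within the scatter) is small, within the usual scatter, perhaps leaning toward stronger inhibition. Compound 3 is estimated at 3000 nM, with a likely range from 800 nM to 12000 nM.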

Compound 3, half-maximal inhibitory concentration: 300 nM
The estimate for compound 3 lay 10-fold (1.00 log units) above the measured number, outside the stated range (below it).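

Changing 4-ethylphenyl to 4-chlorophenyl gives a 15-fold lower number from compound 2 to compound 3 (1.19 log units; beyond the scatter) in this assay, so this place on the aromatic ring, para to a large group, clearly matters for inhibition. A swap of one small group for another, with no hydrogen-bond donors or acceptors on either side, is enough to produce a large step. Nothing shown here explains why the step is this large.

The compounds shown leave open how fluoro, methoxy or an amine at this place would compare with chloro. They also leave open whether the gain comes from having chloro or from losing ethyl.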